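Trimming a Methoxy Group on an Aminophenyl Enone Scaffold

The source may report more compounds than this note shows. Statements on the series, on what has been measured and on what is new or still open speak of the compounds shown alone.

Compound 2 `COc1cc(-c2cc(/C=C/C(=O)c3ccc(N)cc3)[nH]n2)cc(OC)c1OC` has been tested in a functional assay on NCI-H322M cells (Homo sapiens) for inhibition, read by sulforhodamine B assay, with a stated time of 48 h (on this read-out higher numbers stand for lower toxicity in this test and lower numbers for higher toxicity in this test), where compound 2 gives 20900 nM. Its only measured companion, compound 1 `COc1ccc(-c2cc(/C=C/C(=O)c3ccc(N)cc3)[nH]n2)cc1`, gives 31600 nM in this assay. The two numbers lie within the usual scatter of each other, so compound 2 stands together with compound 1 rather than apart from it. Compound 3 `COc1ccc(-c2cc(/C=C/C(=O)c3ccc(N)cc3)[nH]n2)cc1OC` differs from compound 2 by hydrogen in place of methoxy on an aromatic carbon. Among the compounds with values here, no step between measured compounds is available to calibrate this change. Compound 3 is therefore expected to remain within the scatter in this assay, a step of a 1.2-fold higher number from compound 2 to compound 3 (0.08 log units; within the scatter) with no clear direction. Compound 3 is estimated at 25000 nM, in the range 10000 nM to 60000 nM.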

Compound 3, concentration lethal to 50% of the cells: 46200 nM
Compound 3: the middle estimate sits 1.8-fold (0.27 log units) below what was measured, and the stated range covers the measured number.
By their numbers in this assay, from the lowest: compounds 2, 1 and 3 (each within the scatter of the next, the first and the last beyond it).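

In this assay, within the data shown here, the change of methoxy to hydrogen on this aromatic carbon, ortho to a methoxy group, gives a 2.2-fold higher number from compound 2 to compound 3 (0.34 log units; beyond the scatter) and so is the only step here that passes beyond the scatter, if modestly. The reverse kind of change, methoxy in place of hydrogen on an aromatic carbon, gives a 1.5-fold higher number from compound 1 to compound 3 (0.16 log units; within the scatter) and stays within the scatter, so the effect of this change depends on the pair compared. The compounds shown leave open how a hydroxy group or a chlorine atom on this carbon would compare with methoxy and hydrogen. No evidence is available that accounts for either step.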